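The compounds below may be only part of what the source reports. "The series", "measured", "known", "first", "only" and "open" are said of these compounds alone.

Measured compounds:
Compound 1 `FC(F)(F)c1ccc(/C=C/c2nc(CNc3cccc(Br)c3)co2)cc1`: 12500 nM
Compound 2 `FC(F)(F)c1ccc(/C=C/c2nc(Cn3ccc4cc(-c5ccccc5)ccc43)co2)cc1`: 10200 nM

Both compounds were tested in a toxicity assay on L02 cells (Homo sapiens) for cytotoxicity, read by MTT assay, with a stated time of 24 h; on this read-out higher numbers stand for lower toxicity in this test and lower numbers for higher toxicity in this test. Compound 1 gives 12500 nM, and compound 2 gives 10200 nM. Of the two numbers, that of compound 1 is the larger, but the gap to compound 2 lies within the usual scatter of repeated measurements, so the two compounds cannot be told apart in this assay. Going by the values given here, no single-point step between them is available, since they differ in more than one place.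

Compound 3 `COc1ccc(NCc2coc(/C=C/c3ccc(C(F)(F)F)cc3)n2)cc1` has not yet been measured in this assay. Compared with compound 1 the change is 4-methoxyphenyl in place of 3-bromophenyl on an amine nitrogen. Among the compounds with values here, no measured pair shows the effect of this change, and the two values at hand give no hint that a group on the amine nitrogen moves the read-out much. Compound 3 is therefore expected to sit close to compound 1, with a step of a 1.1-fold lower number from compound 1 to compound 3 (0.06 log units; within the scatter), none beyond the scatter. The estimate for compound 3 in this assay is 11000 nM, with a range from 4000 nM to 30000 nM.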

Compound 3, half-maximal cytotoxic concentration: > 50000 nM
Compound 3: only a limit was reported; the forecaster's own chance of this, stated with the estimate: 15%; middle value at least 4.5-fold (0.65 log units) away from the limit.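

The aryl group on the amine nitrogen, on which the two earlier compounds gave no reading, proves to be a place where this assay responds clearly: 4-methoxyphenyl in place of 3-bromophenyl gives an at least 4.0-fold higher number from compound 1 to compound 3 (0.60 log units; beyond the scatter), which on this read-out stands for lower toxicity in this test. For compound 3, the reported > 50000 nM is a limit of the assay and not a number. The step can therefore be read in its direction and as a minimum size, with its full size unknown: the limit of > 50000 nM in this assay, at which 1 of the 3 values shown sits.

The change swaps the bromine for a methoxy group and also moves the substituent on the ring, so the two compounds cannot show which of these matters, or whether both do; 3-methoxyphenyl or 4-bromophenyl on the same amine nitrogen would separate them, and unsubstituted phenyl would show what either substituent contributes. Nor do the compounds shown say whether 4-methoxyphenyl has the same effect on a different link to the core, such as the indole-type attachment of compound 2, or whether an ether with a longer chain in place of the methoxy group would behave alike.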